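Swapping the Side Ring of Compound 1

A few compounds are considered here, and "the series" means these few. Any claim that something is new, unique, unknown or untested is made for them only; others in the source may bear on it.

In an in vitro ADME assay on microsomes from liver (Simiiformes) (a higher number here means that the compound lasts longer, a lower number that the compound disappears faster), compound 1 `CCOCc1cc(CCCOc2c(C)cc(-c3noc(C(F)(F)F)n3)cc2C)on1` gives > 2.5 h, which is a limit of the assay and not a number. Compound 2 `CCc1cc(CCCOc2c(C)cc(-c3noc(C4CC4)n3)cc2C)on1`, with a different structure, gives the only exact half-life so far, 0.9 h. Compound 3 `CC(=O)c1ccc(CCCOc2c(C)cc(-c3noc(C(F)(F)F)n3)cc2C)o1` carries 5-acetylfuran-2-yl in place of 3-(ethoxymethyl)-1,2-oxazol-5-yl on a saturated chain carbon (5-acetylfuran-2-yl in place of 3-(ethoxymethyl)-1,2-oxazol-5-yl on a saturated chain carbon, three bonds along the chain from an oxygen on an aromatic ring). Within the data shown here, no measured pair shows this change, so the expectation leans on compound 2 at 0.9 h. A shorter half-life is expected, an estimated step of an at least 2.0-fold lower number from compound 1 to compound 3 (0.31 log units; beyond the scatter). For compound 3 the estimate is 1.2 h, with an expected range of 0.4 h to 3 h.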

Compound 3, half-life: 1.05 h
Estimate against measurement, compound 3: 1.1-fold (0.06 log units) above; the range from low to high includes it.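

In this assay, among these compounds, the side ring on this chain now has a readable effect for the first time: 5-acetylfuran-2-yl in place of 3-(ethoxymethyl)-1,2-oxazol-5-yl gives an at least 2.3-fold lower number from compound 1 to compound 3 (0.37 log units; beyond the scatter) with the rest of the structure unchanged. From the compounds shown here alone, the true size of this step remains open-ended, because compound 1 gives a limit and not a number: the limit of > 2.5 h in this assay, at which 1 of the 3 values shown sits.

Whether the acetyl group or the furan ring accounts for the shorter half-life remains open. So does the effect of a furan carrying an ethoxymethyl group or a carboxylic acid instead.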